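Swapping the pyridyl for a methylphenyl on an imidazoline ether

A few compounds are considered here, and "the series" means these few. Any claim that something is new, unique, unknown or untested is made for them only; others in the source may bear on it.

Measured so far:
- compound 1, `CC(Oc1ccccc1-c1cccnc1)C1=NCCN1`: 933 nM
- compound 2, `CC(Oc1ccccc1-c1ccncc1)C1=NCCN1`: 2690 nM

In an assay on CHO cells for displacement of a labelled ligand from Alpha-2B adrenergic receptor (Homo sapiens) (on this read-out higher numbers stand for weaker inhibition and lower numbers for stronger inhibition), compound 2 gives 2690 nM, the highest of the two numbers; its nearest neighbour, compound 1, gives 933 nM. Going by the values given here, the one measured step, a 2.9-fold higher number from compound 1 to compound 2 (0.46 log units; beyond the scatter), shows that moving the ring nitrogen alone shifts the number modestly. Compound 3, `Cc1cccc(-c2ccccc2OC(C)C2=NCCN2)c1`, carries the change (3-methylphenyl in place of pyridin-4-yl on an aromatic carbon). Among the compounds with values here, no measured pair covers replacement of the nitrogen-containing ring by a carbon-only ring, so the step from compound 1 to compound 2 is the only guide, and it suggests the aromatic group can move the number by a modest amount in either direction. Compound 3 is therefore expected to land near the range already seen, with a 2.2-fold lower number from compound 2 to compound 3 (0.35 log units; beyond the scatter) as a tentative guess. The estimate for compound 3 is 1200 nM, within 300 nM to 5000 nM.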

Compound 3, inhibition constant: 537 nM
Beside the measured number, compound 3's estimate is 2.2-fold (0.35 log units) above it; low and high end bracket the measured number.
By their numbers in this assay, from the lowest: compounds 3 and 1 (each within the scatter of the next); then compound 2.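

In this assay, the aromatic carbon of the shared core carries a ring of carbon only as well as a pyridine ring, and the new compound sits on the low side of the series. Going by these compounds alone, putting 3-methylphenyl in place of pyridin-4-yl gives the largest step so far (a 5.0-fold lower number from compound 2 to compound 3 (0.70 log units; beyond the scatter)), while putting it in place of pyridin-3-yl gives a step that cannot be told from noise (a 1.7-fold lower number from compound 1 to compound 3 (0.24 log units; within the scatter)), so a ring nitrogen is not needed for a number at the level of compound 1. No supporting data explain why these steps have the sizes they do.

The change to compound 3 both removes the ring nitrogen and adds a methyl group, and a plain phenyl ring would be needed to separate the two. Going by these compounds, how a methoxy group or a chlorine atom in place of that methyl would read also stays open.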